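From Acetyl to Benzoyl on a Short Amide Chain

The source may report more compounds than this note shows. Statements on the series, on what has been measured and on what is new or still open speak of the compounds shown alone.

Within the data shown here, in a functional assay on the whole organism for antagonist activity, with Mus musculus as the target (a lower number here means that less compound is needed, a higher number that more compound is needed for the effect), compound 2 `CC(=O)NCC(=O)N(C)c1ccc(Cl)cc1C(=O)c1ccccc1Cl` gives 2.3 mg/kg and sits at the low end of the numbers so far. Compound 1 `NCC(=O)NCC(=O)Nc1ccc([N+](=O)[O-])cc1C(=O)c1ccccc1Cl` gives 2.64 mg/kg and lies within the usual scatter of compound 2, so the two cannot be told apart. Compound 3 `NC(C(=O)NCC(=O)Nc1ccc(Cl)cc1C(=O)c1ccccc1)c1ccccc1` gives 28 mg/kg and so needs clearly more compound than either of them.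

Compound 4 `CN(C(=O)CNC(=O)c1ccccc1)c1ccc(Cl)cc1C(=O)c1ccccc1Cl` has not yet been measured. It keeps everything in compound 2 except one group, and the change reads phenyl in place of methyl on a carbonyl carbon in full: phenyl in place of methyl on a carbonyl carbon, so that acetamido becomes benzamido.

Among the measured compounds shown here, no measured pair of compounds shows this exact change, so there is no direct guide. For the measured compounds named here, the nearest hint is compound 3 at 28 mg/kg as the only measured compound with a phenyl group on its chain, but it also differs from compound 2 in other places and proves little. The expected step is a 2.6-fold higher number from compound 2 to compound 4 (0.42 log units; beyond the scatter) in this assay and points toward a higher number, modest in size and only a little beyond the scatter. For compound 4 the estimated value is 6 mg/kg with 2 mg/kg to 20 mg/kg as its expected range.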

Compound 4, dose for half-maximal effect: 2.9 mg/kg
Compound 4: middle estimate off by 2.1-fold (0.32 log units), on the high side; the range from low to high includes it.
By their numbers in this assay, from the lowest: compounds 2, 1 and 4 (each within the scatter of the next); then compound 3.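

In this assay, putting phenyl in place of methyl on a carbonyl carbon, so that acetamido becomes benzamido, gives a 1.3-fold higher number from compound 2 to compound 4 (0.10 log units; within the scatter), a difference too small to separate from the spread of repeated measurements. The earlier compounds shown here offered no matched pair for this position; this pair shows that here a whole aromatic ring can stand where a methyl stood without a detectable change in the dose needed in this whole-animal test. Among these compounds, nothing measured so far explains why the dose stays level across this change.

Going by these compounds, only methyl and phenyl can be compared at this carbonyl carbon, so it remains open whether the same would hold for a longer chain, a benzyl group, or a phenyl ring carrying an amine or a carboxylic acid. On these data alone, it is also open whether phenyl would behave the same way in place of methyl on a different core, since this single pair speaks only for the core shared by compound 2 and compound 4.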